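Second fluoro on the aromatic ring of compound 2

The source may hold more compounds than are shown below. What is called first, only, known or untested is meant among the compounds shown, and "the series" means these compounds.

Compound 1 `N#Cc1ccc2c(c1)C1CNCC2C1` and compound 2 `Fc1ccc2c(c1)C1CNCC2C1` share one core; in an assay on HEK293 cells for binding affinity to Neuronal acetylcholine receptor; alpha4/beta2 (Homo sapiens) (on this read-out higher numbers stand for weaker inhibition and lower numbers for stronger inhibition), compound 1 gives 0.5 nM and compound 2 gives 1.1 nM, the higher of the two numbers. Within the data shown here, the single measured step, a 2.2-fold higher number from compound 1 to compound 2 (0.34 log units; beyond the scatter), swaps cyano for fluoro. Compound 3 `Fc1cc2c(cc1F)C1CNCC2C1` differs from compound 2 by fluoro in place of hydrogen on an aromatic carbon. Among the measured compounds shown here, no measured step adds a group to the ring, so the swap only gives a feel for scale. A small step, not clearly beyond the scatter, is expected, a 1.4-fold higher number from compound 2 to compound 3 (0.13 log units; within the scatter), in either direction. The estimate for compound 3 in this assay is 1.5 nM, range 0.6 nM to 4 nM.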

Compound 3, inhibition constant: 0.28 nM
Compound 3: middle estimate off by 5.4-fold (0.73 log units), on the high side, and the stated range ends above it.
By their numbers in this assay, from the lowest: compounds 3 and 1 (each within the scatter of the next); then compound 2.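

On the aromatic carbon ortho to a fluoro group, hydrogen is not a neutral site: in this assay the added fluoro gives a 3.9-fold lower number from compound 2 to compound 3 (0.59 log units; beyond the scatter), so this single heavy atom moves the read-out toward stronger inhibition. The earlier compounds shown here showed only a swap of one group for another, not the effect of filling a further ring carbon. Nothing measured on hand accounts for this step.

Open, on these data alone, is whether chloro, methoxy or an amine on this carbon would act as fluoro does. Also open, as far as these compounds go, is whether this fluoro would give the same step without the fluoro already present in compound 2.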